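The source may hold more compounds than are shown below. What is called first, only, known or untested is meant among the compounds shown, and "the series" means these compounds.

Measured compounds in a functional assay on CCRF-CEM cells (Homo sapiens) for cytotoxicity, read by cell counting, with a stated time of 3 days; on this read-out higher numbers stand for weaker inhibition and lower numbers for stronger inhibition:

Compound 1 `C=C(Br)C(=O)Nc1ccc(/C=C2\SC(=O)N(Cc3cccc(F)c3)C2=O)cc1` gives 3200 nM.
Compound 2 `Nc1cccc(/C=C2\SC(=O)N(Cc3cccc(F)c3)C2=O)c1` gives 250000 nM.
Compound 3 `C=C(Br)C(=O)Nc1cccc(/C=C2\SC(=O)N(Cc3cccc(Cl)c3)C2=O)c1` gives 1400 nM.

Of these three, compound 3 has the lowest number in this assay. Its nearest neighbour is compound 1, whose number is higher by an amount beyond the usual scatter; compound 2 lies much further away, with a number higher by a wide margin. Among the measured compounds shown here, no two of the measured compounds differ in only one place, so no single step between them is available to lean on.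

Compound 4 `C=C(Br)C(=O)Nc1cccc(/C=C2\SC(=O)N(Cc3ccc(C(F)(F)F)cc3)C2=O)c1` has not yet been measured. It differs from compound 3 in one place: 4-(trifluoromethyl)phenyl in place of 3-chlorophenyl on a saturated chain carbon bound to an amide-type nitrogen in a ring. Both groups that leave and enter carry no hydrogen-bond donors or acceptors and no net charge, and both hold one six-membered aromatic ring of carbon only.

For the measured compounds named here, with no measured step of this kind to rest on, she expects the step from compound 3 to compound 4 in this assay to be small, most likely within the scatter, with a slight lean toward a higher number: a 1.4-fold higher number from compound 3 to compound 4 (0.15 log units; within the scatter). Her estimate for compound 4 is therefore 2000 nM, with a range from 600 nM to 7000 nM.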

Compound 4, half-maximal inhibitory concentration: 920 nM
Compound 4: middle estimate off by 2.2-fold (0.34 log units), on the high side, within the range that was stated.
By their numbers in this assay, from the lowest: compounds 4 and 3 (each within the scatter of the next); then compound 1; then compound 2.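

In this assay, among the compounds shown here, this is the first single change that can be read at this position, and a 1.5-fold lower number from compound 3 to compound 4 (0.18 log units; within the scatter) leaves compound 3 and compound 4 indistinguishable. The change is not a minimal one: the entering 4-(trifluoromethyl)phenyl holds 10 heavy atoms against 7 in the leaving 3-chlorophenyl, and the substituent differs in both its kind and its place on the aromatic ring. For these two compounds, then, the saturated chain carbon bound to an amide-type nitrogen in a ring carries either group with no difference beyond the scatter, although no measurement shown speaks to why the two compounds match.

The compounds shown leave open how the kind of substituent and its place on the ring each count alone, since 4-chlorophenyl and 3-(trifluoromethyl)phenyl do not stand among them. They also leave open whether an amine or a carboxylic acid on the aromatic ring, or a longer chain on the ring nitrogen, would give a number like these in this assay.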